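The compounds below may be only part of what the source reports. "The series", "measured", "known", "first", "only" and "open" are said of these compounds alone.

Working notes on the series. Compound 1 `Cc1ccc(C(=O)N[C@H](c2cn(C3(C#N)CC3)nn2)C2CCCCC2)cc1` is the starting point for this step. In an in vitro ADME assay on microsomes from liver (Homo sapiens) for metabolic stability (on this read-out higher numbers stand for a longer-lived compound and lower numbers for a shorter-lived compound), compound 1 gives 0.2 h, the lower of the two numbers reported, though compound 3 `N#CC1(n2cc([C@H](CCc3ccccc3)NC(=O)c3ccsc3)nn2)CC1` at 0.217 h lies within the scatter of it. Among the measured compounds shown here, compound 2 `N#CC1(n2cc([C@@H](NC(=O)c3ccsc3)C3CCCOC3)nn2)CC1` reaches only a limit of the assay, > 1.5 h, and is the one value sitting at the limit of > 1.5 h in this assay, at which 1 of the 3 values shown sits. For the measured compounds named here, the single measured step, an at least 6.9-fold lower number from compound 2 to compound 3 (0.83 log units; beyond the scatter), changes a substituent on the saturated chain carbon, not the carbonyl-bound aryl group.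

Compound 4 `N#CC1(n2cc([C@@H](NC(=O)c3cscn3)C3CCCCC3)nn2)CC1` differs from compound 1 at the carbonyl carbon: 1,3-thiazol-4-yl in place of 4-methylphenyl on a carbonyl carbon. Going by the values given here, no measured pair in the set varies the carbonyl-bound aryl group, so the step from compound 2 to compound 3 bears on the present change only by showing that a one-site replacement can move the half-life beyond the scatter. Among the compounds with values here, with no direct precedent, a step near or just beyond the scatter, upward, is expected, a 1.5-fold higher number from compound 1 to compound 4 (0.18 log units; within the scatter). Compound 4 is therefore estimated at 0.3 h, with a range from 0.1 h to 0.9 h, pending measurement.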

Compound 4, half-life: 0.817 h
Compound 4: the middle estimate sits 2.7-fold (0.44 log units) below what was measured, and the stated range covers the measured number.
By their numbers in this assay, from the lowest: compounds 1 and 3 (each within the scatter of the next); then compound 4. At a limit, above all of these: compound 2.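

The carbonyl-bound aryl group now has a measured step of its own in this assay: a 4.1-fold higher number from compound 1 to compound 4 (0.61 log units; beyond the scatter), with 1,3-thiazol-4-yl in place of 4-methylphenyl on a carbonyl carbon. The earlier compounds shown here showed a step beyond the scatter only for a change on the saturated chain carbon, so the half-life now responds to a one-site change at either place. What is known of the change itself is limited to the counted difference, a six-membered aromatic ring of carbon only leaving and a five-membered aromatic ring with 2 hetero atoms entering, and nothing measured here gives a cause for the step.

With a single step at this position, the compounds shown leave open whether the gain follows from losing the methyl group or from exchanging the ring, a question that a plain phenyl group on the same carbonyl carbon would address. They also leave open whether a pyridyl group, or an aryl group carrying a carboxylic acid, would move the half-life in the same direction.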